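The source may hold more compounds than are shown below. What is called first, only, known or untested is meant among the compounds shown, and "the series" means these compounds.

For the measured compounds named here, compound 1 `O=Cc1ccc(-c2cn3ccnc3c(-c3ccc4ncn(C5CCCCC5)c4c3)n2)cc1` is one of only two compounds measured in a functional assay on NCI-H460 cells (Homo sapiens) for inhibition, read by sulforhodamine B assay, with a stated time of 48 h, tested at 10 uM; a higher number here means more inhibition at the concentration tested (going by the name of the read-out), a lower number less inhibition; in this assay compound 1 gives 37.8%, the higher of the two numbers. Compound 2 `c1ccc2c(-c3cn4ccnc4c(-c4ccc5ncn(C6CCCCC6)c5c4)n3)cccc2c1` differs from it in one place, and compound 2 gives 3.61%. Going by the values given here, the single measured step, a number 34.2 percentage points lower from compound 1 to compound 2 (beyond the scatter), shows that exchanging the group at this point of the shared core can move the read-out a long way.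

Compound 3 `Brc1ccc(-c2cn3ccnc3c(-c3ccc4ncn(C5CCCCC5)c4c3)n2)cc1` has not been measured. Its difference from compound 1 is bromo in place of formyl on an aromatic carbon. Among the compounds with values here, only the step from compound 1 to compound 2 bears on this change, and only loosely, since there the whole 4-formylphenyl was exchanged for naphthalen-1-yl rather than a single substituent being swapped. That step was large and downward, and compound 2, which like compound 3 carries no hydrogen-bond acceptor at this place, gave the lower number. A downward step is therefore expected, roughly a number 17.8 percentage points lower from compound 1 to compound 3 (beyond the scatter), though smaller than the measured one and with wide uncertainty. For compound 3 the estimate in this assay is 20%, with a range from 5% to 40%.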

Compound 3, a percentage reported as inhibition, at one concentration (the size of the read-out at that concentration, not a potency): 13.2%
The estimate for compound 3 lay 6.8 percentage points above the measured number; low and high end bracket the measured number.
By their numbers in this assay, from the lowest: compounds 2 and 3 (each within the scatter of the next); then compound 1.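

Exchanging only the formyl for bromo, with the phenyl ring kept in place, gives in this assay a number 24.6 percentage points lower from compound 1 to compound 3 (beyond the scatter), so a change of this single substituent, para to a large group, is enough to beyond-scatter lower the read-out, and the whole 4-formylphenyl need not be exchanged. Compound 3 also sits close to compound 2, with a number 9.6 percentage points higher from compound 2 to compound 3 (within the scatter), so 4-bromophenyl and naphthalen-1-yl, two different groups without the formyl, cannot be told apart here. No measurement at hand explains what the formyl contributes at this position.

The compounds shown leave open whether the higher number belongs to the formyl group alone, or whether a carboxylic acid, an acetyl group or an aminomethyl group at the same place would give a similar read-out, and where a plain phenyl ring would fall. Since each number is the size of the read-out at one concentration, they also leave open how far these compounds differ in potency.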